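Amino for chloro on the dichloropurine-type core of compound 1

The source may hold more compounds than are shown below. What is called first, only, known or untested is meant among the compounds shown, and "the series" means these compounds.

Compound 1 `ClCc1cccc(Cn2cnc3c(Cl)nc(Cl)nc32)c1` gives 2230 nM in a functional assay on COLO 205 cells (Homo sapiens) for cytotoxicity, read by sulforhodamine B assay, with a stated time of 48 h (a higher number here means a weaker inhibitor of growth, a lower number a stronger inhibitor of growth), the second highest of the three numbers recorded. The nearest is compound 2 `Nc1nc(Cl)c2ncn(Cc3ccccc3CCl)c2n1` with 5010 nM, a higher number beyond the scatter; furthest is compound 3 `ClCc1cccc(Cn2cnc3nc(Cl)nc(Cl)c32)c1` with 410 nM, a lower number, also beyond the scatter. No pair among these three differs in one place only, so no single-point step is available.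

Compound 4 `Nc1nc(Cl)c2ncn(Cc3cccc(CCl)c3)c2n1` differs from compound 1 as follows: amino in place of chloro on an aromatic carbon. Compound 2, which carries the amino group, sits at the weak end of the series but also differs in the benzyl substitution, so it does not isolate this change. A small step toward a higher number, or none beyond the scatter, is expected for compound 4 in this assay, a 1.6-fold higher number from compound 1 to compound 4 (0.20 log units; within the scatter). Compound 4 is estimated at 3500 nM, in the range 1500 nM to 8000 nM.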

Compound 4, concentration for 50% growth inhibition: 6760 nM
The estimate for compound 4 lay 1.9-fold (0.29 log units) below the measured number; the range from low to high includes it.
By their numbers in this assay, from the lowest: compound 3; then compound 1; then compounds 2 and 4 (each within the scatter of the next).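

Amino in place of chloro on this aromatic carbon, between two ring nitrogen atoms, gives the first single-place step in the series, and in this assay it runs toward weaker growth inhibition (a 3.0-fold higher number from compound 1 to compound 4 (0.48 log units; beyond the scatter)). At this position, then, amino does not stand in for chloro without loss. Nothing at hand explains the step.

Going by these compounds, whether the loss follows from adding amino or from removing chloro stays open. A methoxy or methyl group on the same carbon would help separate the two.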